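The source may report more compounds than this note shows. Statements on the series, on what has been measured and on what is new or still open speak of the compounds shown alone.

Measured compounds in an assay on HEK293 cells for binding affinity to adenosine receptor A2b (Homo sapiens), read by radioligand binding; on this read-out higher numbers stand for weaker inhibition and lower numbers for stronger inhibition:
compound 1 `CC(C)CCn1c(=O)c2nc[nH]c2n(CC(C)C)c1=O` gives 6240 nM
compound 2 `COCn1c(=O)c2c(ncn2C)n(C)c1=O` gives 14000 nM
compound 3 `Cn1cnc2c1c(=O)n(CC#N)c(=O)n2C` gives 21600 nM

Compound 3 stands at the highest number of the three in this assay. Its nearest neighbour is compound 2, and the step of a 1.5-fold higher number from compound 2 to compound 3 (0.19 log units; within the scatter) falls within the scatter. Within the data shown here, compound 1 is furthest away, with a clearly lower number; the gap to compound 3 lies beyond the scatter, but the two structures differ in several places and no single step is drawn between them.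

Compound 4 `CC(=O)Cn1c(=O)c2c(ncn2C)n(C)c1=O` differs from compound 3 by acetyl in place of cyano on a saturated chain carbon bound to an aromatic nitrogen. Among the measured compounds shown here, the only measured step at that position is the exchange of methoxy for cyano, a 1.5-fold higher number from compound 2 to compound 3 (0.19 log units; within the scatter), which did not move the number beyond the scatter. For the measured compounds named here, with one small step as the sole guide, no movement beyond the scatter is expected for the exchange of cyano for acetyl either; a modest shift toward a lower number, a 1.4-fold lower number from compound 3 to compound 4 (0.16 log units; within the scatter), is the estimate. Compound 4 is therefore expected to give about 15000 nM in this assay, within a range of 5000 nM to 45000 nM.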

Compound 4, inhibition constant: 20800 nM
Compound 4: middle estimate off by 1.4-fold (0.14 log units), on the low side; low and high end bracket the measured number.
By their numbers in this assay, from the lowest: compound 1; then compounds 2, 4 and 3 (each within the scatter of the next).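

In this assay, acetyl in place of cyano on a saturated chain carbon bound to an aromatic nitrogen gives (a 1.0-fold lower number from compound 3 to compound 4 (0.02 log units; within the scatter)), and acetyl in place of methoxy at the same place gives (a 1.5-fold higher number from compound 2 to compound 4 (0.17 log units; within the scatter)). With the earlier exchange of methoxy for cyano, all three steps among these groups now lie within the scatter, so methoxy, cyano and acetyl are not told apart at this position on the shared core, where one step alone could show only a single pair. No evidence in hand explains this lack of separation.

From the compounds shown here alone, whether an amine, a carboxylic acid or a longer chain at this position would move the number beyond the scatter remains open. Compound 1 (6240 nM) differs from these compounds in several places, so no single place can be tied to its number.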